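From Isopropyl to Heptyl: What Compound 4 Might Show

The source may report more compounds than this note shows. Statements on the series, on what has been measured and on what is new or still open speak of the compounds shown alone.

Compound 1 `CC(C)c1cccc(NC(=O)N[C@@H](C)c2ccccc2)c1`: in an ADME assay on the whole organism with Oryza sativa as the target, tested at 0.1 uM (on this read-out higher numbers stand for a weaker effect at the one concentration tested and lower numbers for a stronger effect), compound 1 gives 95%.
Compound 2 `CC(C)c1ccc(NC(=O)N[C@H](C)c2ccccc2)cc1`: in this assay compound 2 gives 99%.
Compound 3 `CC(C)c1ccc(NC(=O)N[C@@H](C)c2ccccc2)cc1`: in this assay compound 3 gives 98%.

Compound 3 stands second highest of the three numbers in this assay; compound 2 is its nearest neighbour and compound 1 lies furthest from it, yet all three values fall within the scatter of one another, so no order among them can be read. Among the compounds with values here, the only step between two compounds that differ in one place is a number 1 percentage points lower from compound 2 to compound 3 (within the scatter), and because the fact that compounds 2 and 3 differ only in the configuration as drawn that step speaks solely to configuration and not to any exchange of a group on the ring.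

Compound 4 `CCCCCCCc1ccc(NC(=O)N[C@@H](C)c2ccccc2)cc1` has not yet been measured. The change from compound 3 is heptyl in place of isopropyl on an aromatic carbon. None of the measured steps concerns an exchange of one chain for another, so nothing shown here points in either direction. The expected step is therefore a number 2 percentage points lower from compound 3 to compound 4 (within the scatter), nothing beyond the scatter. For compound 4 in this assay the estimate is 96%, with a range from 85% to 100%.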

Compound 4, a percentage reported as activity, at one concentration (the size of the read-out at that concentration, not a potency): 100%
Compound 4: the middle estimate sits 4 percentage points below what was measured; the measured number falls inside the stated range.
By their numbers in this assay, from the lowest: compounds 1, 3, 2 and 4 (each within the scatter of the next).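

The exchange of isopropyl for heptyl on an aromatic carbon, para to a large group, comes with a number 2 percentage points higher from compound 3 to compound 4 (within the scatter) in this assay. This is the only step shown that swaps one chain for another, and it shows that, at the one concentration tested, this position accepts the added chain length with no change that can be read from the scatter. Nothing known about these compounds bears on this step.

On these data alone, it remains open whether a different group on the same aromatic carbon, such as an amine, a carboxylic acid or a chain longer than heptyl, would move the number beyond the scatter. Also open, as far as these compounds go, is whether heptyl would give the same picture at another concentration or with the opposite configuration as drawn.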